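Two Places for One Chloro-in-Place-of-Methyl Change

The source may report more compounds than this note shows. Statements on the series, on what has been measured and on what is new or still open speak of the compounds shown alone.

Compound 1 `Cc1c(CO)cccc1NS(=O)(=O)c1ccc(-c2ccc(Br)cc2)cc1`, in an ADME assay on microsomes from liver (Homo sapiens) for metabolic stability, read by LC-MS, tested at 3 uM (a lower number here means that the compound disappears faster, a higher number that the compound lasts longer), gives 0.567 h.
Compound 2 `Cc1ccc(CO)cc1NS(=O)(=O)c1ccc(-c2ccc(Br)cc2)cc1` in this assay gives 0.15 h.
Compound 3 `O=S(=O)(Nc1cccc(CO)c1Cl)c1ccc(-c2ccc(Br)cc2)cc1` in this assay gives 0.933 h.

Compounds 1 and 3 share a core and differ in one place: chloro in place of methyl on an aromatic carbon. That change gave a 1.6-fold higher number from compound 1 to compound 3 (0.22 log units; within the scatter), so the two numbers cannot be told apart with confidence. Compound 2 is built from the same atoms as compound 1, joined differently; the difference between the two cores is not broken down here. In this assay compound 2 stands lowest of the three, with compound 1 nearest and compound 3 furthest, both gaps beyond the usual scatter.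

Compound 4 `O=S(=O)(Nc1cc(CO)ccc1Cl)c1ccc(-c2ccc(Br)cc2)cc1` has not yet been measured. It differs from compound 2 by chloro in place of methyl on an aromatic carbon. Among the compounds with values here, this is the same kind of change as the one from compound 1 to compound 3, but the surroundings differ: in compound 3 the chloro sits ortho to a hydroxymethyl group and ortho to a large group, whereas in compound 4 it sits ortho to a large group and para to a hydroxymethyl group.

The step from compound 2 to compound 4 in this assay is expected to be a 1.6-fold higher number from compound 2 to compound 4 (0.20 log units; within the scatter), set beside a 1.6-fold higher number from compound 1 to compound 3 (0.22 log units; within the scatter). Within the data shown here, this expectation rests on the single measured step from compound 1 to compound 3, a 1.6-fold higher number from compound 1 to compound 3 (0.22 log units; within the scatter), and on nothing else. For compound 4 the expected number in this assay is 0.24 h. The expected range for compound 4 runs from 0.12 h to 0.5 h.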

Compound 4, half-life: 0.75 h
Compound 4: middle estimate off by 3.1-fold (0.49 log units), on the low side; the measured number lies above the stated range.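

In this assay, chloro in place of methyl on an aromatic carbon gave a 5.0-fold higher number from compound 2 to compound 4 (0.70 log units; beyond the scatter), a clear change on the core of compound 2. The same swap did not carry over at the same size between the two cores, and the gap between its two results is larger than chance scatter would readily give: the same change on two cores in this assay, a 1.6-fold higher number (0.22 log units; within the scatter) from compound 1 to compound 3 and a 5.0-fold higher number (0.70 log units; beyond the scatter) from compound 2 to compound 4, 3.0-fold (0.48 log units) apart, beyond the scatter of two such steps

This shows that in this small series, the size of the step on one core was a poor guide to its size on the other, so the result of this swap has to be measured on each core rather than copied across. Within the data shown here, it does not show why the two steps differ, and with only one pair on each core, it gives no general rule for how this change behaves in other compounds.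

At this place the compounds shown carry only methyl or chloro, so it remains open whether fluoro, a methoxy group or an amine would follow the large step or the small one. Going by these compounds, it also remains open how the step would change with a carboxylic acid or a longer chain in place of the hydroxymethyl group.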